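Replacing a cyclic amine with an open-chain one

The source may report more compounds than this note shows. Statements on the series, on what has been measured and on what is new or still open speak of the compounds shown alone.

Compound 1 `CCCN(CCC)S(=O)(=O)c1ccc(S(=O)(=O)N2CCC[C@@H](C(=O)OCC)C2)cc1`: 2300 nM
Compound 2 `CCOC(=O)[C@@H]1CCCN(S(=O)(=O)c2ccc(S(=O)(=O)N3CCOCC3)cc2)C1`: 23500 nM
Compound 3 `CCOC(=O)[C@@H]1CCCN(S(=O)(=O)c2ccc(S(=O)(=O)N3CCNCC3)cc2)C1`: > 30000 nM

Three compounds share one core and differ only in the amine attached to a sulfonyl sulfur. In a functional assay on MIA PaCa-2 cells (Homo sapiens) for inhibition, read by MTT assay, with a stated time of 7 days (on this read-out higher numbers stand for weaker inhibition and lower numbers for stronger inhibition), compound 1 gives 2300 nM. In this assay compound 2 gives 23500 nM. For compound 3 the assay reports only a limit, > 30000 nM, so compound 3 stands at the weak end of what was measured (the limit of > 30000 nM in this assay, at which 1 of the 3 values shown sits). Going from compound 1 to compound 2 costs a 10-fold higher number from compound 1 to compound 2 (1.01 log units; beyond the scatter), and going from compound 1 to compound 3 costs an at least 13-fold higher number from compound 1 to compound 3 (1.11 log units; beyond the scatter); between compound 2 and compound 3 the step is an at least 1.2-fold higher number from compound 2 to compound 3 (0.10 log units; that floor lies within the scatter).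

Compound 4 `CCCN(CC)S(=O)(=O)c1ccc(S(=O)(=O)N2CCC[C@@H](C(=O)OCC)C2)cc1` is not yet measured. It differs from compound 3 by ethyl(propyl)amino in place of piperazin-1-yl on a sulfonyl sulfur. This change largely reverses the step from compound 1 to compound 3, since ethyl(propyl)amino resembles dipropylamino in having no ring. A large step toward stronger inhibition is therefore expected, an at least 10-fold lower number from compound 3 to compound 4 (1.00 log units; beyond the scatter). Compound 4 is estimated at 3000 nM, within 1200 nM to 9000 nM.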

Compound 4, half-maximal inhibitory concentration: 300 nM
Compound 4: the middle estimate sits 10-fold (1.00 log units) above what was measured; measured number below the stated range.
By their numbers in this assay, from the lowest: compound 4; then compound 1; then compound 2. At a limit, above all of these: compound 3.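

In this assay, an open-chain amine on the sulfonyl sulfur does not merely recover what the ring amines lost: ethyl(propyl)amino gives a 78-fold lower number from compound 2 to compound 4 (1.89 log units; beyond the scatter) against morpholin-4-yl and an at least 100-fold lower number from compound 3 to compound 4 (2.00 log units; beyond the scatter) against piperazin-1-yl. The earlier compounds shown here did not show that the open-chain group itself is sensitive to its length, yet trimming one propyl chain to ethyl gives a 7.7-fold lower number from compound 1 to compound 4 (0.88 log units; beyond the scatter). The step against piperazin-1-yl is only a floor, because compound 3 has a limit rather than a number: the limit of > 30000 nM in this assay, at which 1 of the 4 values shown sits.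

Whether diethylamino would extend this gain remains open, since only two open-chain amines are shown. Piperidin-1-yl, a ring with no second hetero atom, would be needed to separate the effect of having a ring from that of the extra oxygen or nitrogen.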